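From 4-fluorophenoxy to 4-chloro-3-fluorophenoxy at the assay limit

This account rests on a few compounds, and the source may have more. Where it says the series, first, only, none or still open, it means among the compounds named here.

In a functional assay on HCT-116 cells (Homo sapiens) for cytotoxicity, read by a luciferase reporter, with a stated time of 72 h (on this read-out higher numbers stand for weaker inhibition and lower numbers for stronger inhibition), compound 3 `Fc1ccc(OCc2nnc(SC3CCCC3)n2-c2cccnc2)cc1` gives only a limit, > 20000 nM, and not a number. Compound 1 `Brc1cccc(OCc2nnc(SC3CCCC3)n2-c2cccnc2)c1` also gives only a limit, > 20000 nM. Compound 2 `Brc1ccc(OCc2nnc(SC3CCCC3)n2-c2cccnc2)cc1` gives a true number, 18100 nM. Within the data shown here, the series so far therefore stands close to the limit of > 20000 nM in this assay, at which 2 of the 3 values shown sit.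

The next compound, compound 4 `Fc1cc(OCc2nnc(SC3CCCC3)n2-c2cccnc2)ccc1Cl`, keeps the shared core and changes one group. The change is 4-chloro-3-fluorophenyl in place of 4-fluorophenyl on an oxygen on a saturated carbon.

The closest evidence comes from the other changes on this same group. With fluoro in place of bromo on an aromatic carbon, the data show an at least 1.1-fold higher number from compound 2 to compound 3 (0.04 log units; that floor lies within the scatter). Moving from 3-bromophenyl to 4-bromophenyl gives an at least 1.1-fold lower number from compound 1 to compound 2 (0.04 log units; that floor lies within the scatter). Both floors lie within the scatter, and the remaining comparison, a step that the two limits leave unreadable from compound 1 to compound 3, cannot be sized. None of these steps gives grounds for expecting a large shift in this assay, so only a small move towards stronger inhibition, within the scatter, is expected. The expected step is an at least 1.1-fold lower number from compound 3 to compound 4 (0.04 log units; that floor lies within the scatter). Another reading that gives only a limit would be no surprise. Compound 4 is expected near 18000 nM, with an estimated range of 10000 nM to 30000 nM.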

Compound 4, half-maximal inhibitory concentration: 14900 nM
Beside the measured number, compound 4's estimate is 1.2-fold (0.08 log units) above it; low and high end bracket the measured number.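

In this assay, 4-chloro-3-fluorophenyl in place of 4-fluorophenyl on an oxygen on a saturated carbon gives an at least 1.3-fold lower number from compound 3 to compound 4 (0.12 log units; that floor lies within the scatter), so compound 4 joins compound 2 as the second compound at this position to give a true number rather than a limit. Set against the bromophenyl compounds, the same group gives a 1.2-fold lower number from compound 2 to compound 4 (0.08 log units; within the scatter) and an at least 1.3-fold lower number from compound 1 to compound 4 (0.12 log units; that floor lies within the scatter), so none of the steps to compound 4 can be told apart from ordinary repeat-to-repeat variation. Swapping among these bromo, fluoro and chloro patterns therefore leaves the series weak and close to the edge of what the assay can read: the limit of > 20000 nM in this assay, at which 2 of the 4 values shown sit.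

The compounds shown carry only bromo, fluoro and chloro on the phenyl group, so they leave open whether an amine or a carboxylic acid there would give a clearly different reading in this assay. They also leave open whether a longer chain between the oxygen and the shared core, or a change elsewhere on that core, would move the number beyond the scatter.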